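Dropping the Hydroxy Group: Compound 2 to Compound 4

The compounds below may be only part of what the source reports. "The series", "measured", "known", "first", "only" and "open" are said of these compounds alone.

Measured so far:
Compound 1, `O=C(O)c1ccc(S(=O)(=O)N[C@@H](CNC(=O)c2ccc(N3CCC(NC4=NCCCN4)CC3)c(F)c2)C(=O)O)cc1`: 930 nM
Compound 2, `O=C(NC[C@H](NS(=O)(=O)c1ccccc1)C(=O)O)c1ccc(N2CCC(NC3=NCCCN3)CC2)c(O)c1`: 170 nM
Compound 3, `O=C(NC[C@H](NS(=O)(=O)c1ccccc1)C(=O)O)c1ccc(N2CCC[C@H](NC3=NCCCN3)C2)cc1`: 83 nM

These three compounds were tested in a functional assay on a cell-free system (Platelet, plasma, Homo sapiens) for inhibition; a higher number here means a weaker inhibitor, a lower number a stronger inhibitor. Compound 2 stands second highest of the three numbers: compound 3 lies below it, beyond the scatter, and compound 1 lies well above it, also beyond the scatter.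

The next compound, compound 4, `O=C(NC[C@H](NS(=O)(=O)c1ccccc1)C(=O)O)c1ccc(N2CCC(NC3=NCCCN3)CC2)cc1`, differs from compound 2 in one place: hydrogen in place of hydroxy on an aromatic carbon. The hydroxy leaves and a hydrogen enters on the aromatic carbon. Going by the values given here, no measured pair here shows this exact change, so the direction is open. The step of a 1.3-fold lower number from compound 2 to compound 4 (0.12 log units; within the scatter) is expected to be small, within or close to the scatter. In this assay compound 4 is estimated at 130 nM, between 45 nM and 400 nM.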

Compound 4, half-maximal inhibitory concentration: 290 nM
The estimate for compound 4 lay 2.2-fold (0.35 log units) below the measured number; measured number inside the range.
By their numbers in this assay, from the lowest: compound 3; then compounds 2 and 4 (each within the scatter of the next); then compound 1.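

In this assay, going by these compounds alone, hydrogen in place of hydroxy on this aromatic carbon gives a 1.7-fold higher number from compound 2 to compound 4 (0.23 log units; within the scatter) for the first pair that isolates this one change. At this position, ortho to a large group and meta to a large group, the hydroxy therefore has no effect that can be told from the scatter. No measurement here offers a reason for this result.

As far as these compounds go, whether a methoxy group or an amine on the same aromatic carbon would move the number stays open. So does whether the same swap would give a similar result on another core.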